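This account rests on a few compounds, and the source may have more. Where it says the series, first, only, none or still open, it means among the compounds named here.

Compound 1 `CCCCc1ccc2[nH]c(-c3ccc(OC)cc3)c(C=O)c2c1` and compound 2 `COc1ccc(-c2[nH]c3ccc(C)cc3c2C=O)cc1` share a common core and differ in a single place: hydrogen in place of propyl on a saturated chain carbon bound to an aromatic carbon. In a functional assay on MCF7 cells (Homo sapiens) for antiproliferative activity, with a stated time of 5 days (on this read-out lower numbers stand for stronger inhibition and higher numbers for weaker inhibition), compound 1 gives 22 nM, whereas compound 2 gives 140 nM. That change produced a 6.4-fold higher number from compound 1 to compound 2 (0.80 log units; beyond the scatter), a shift that lies beyond the usual scatter of this assay.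

Compound 3 `CCCCc1ccc2[nH]c(-c3ccc(OC)cc3)c(/C=N/NC(=O)c3ccncc3)c2c1` carries a different core, and how its core differs from that of compound 1 is not broken down here. In this assay compound 3 gives 69 nM, which places it second highest among the three measured numbers, with compound 2 nearest and compound 1 furthest.

Compound 4 `COc1ccc(-c2[nH]c3ccc(C)cc3c2/C=N/NC(=O)c2ccncc2)cc1` has not yet been measured. Set against compound 3, compound 4 shows (hydrogen in place of propyl on a saturated chain carbon bound to an aromatic carbon), the same change that separates compound 1 from compound 2, and at the same kind of place in both pairs. Among the compounds with values here, since the single measured instance of this change, a 6.4-fold higher number from compound 1 to compound 2 (0.80 log units; beyond the scatter), moved the number upward beyond the scatter, a step of similar direction and size is expected here, though with only one precedent the size is uncertain. The step from compound 3 to compound 4 is therefore estimated as a 5.8-fold higher number from compound 3 to compound 4 (0.76 log units; beyond the scatter). Compound 4 is accordingly expected to give about 400 nM in this assay, with a plausible range from 150 nM to 1200 nM.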

Compound 4, half-maximal inhibitory concentration: 200 nM
Beside the measured number, compound 4's estimate is 2.0-fold (0.30 log units) above it; the range from low to high includes it.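

In this assay, hydrogen in place of propyl on a saturated chain carbon bound to an aromatic carbon again raised the number, giving a 2.9-fold higher number from compound 3 to compound 4 (0.46 log units; beyond the scatter), so the change ran in the same direction on the second core as on the first. Set side by side, the two steps cannot be told apart in size: the same change on two cores in this assay, a 6.4-fold higher number (0.80 log units; beyond the scatter) from compound 1 to compound 2 and a 2.9-fold higher number (0.46 log units; beyond the scatter) from compound 3 to compound 4, 2.2-fold (0.34 log units) apart, within the scatter of two such steps. This shows that the change carried over from one core to the other in this series, in direction and within the scatter in size, but two pairs make no rule for other cores and give no reason why the number moves.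

The compounds shown hold only butyl and methyl at this place, so it remains open how a chain of another length, such as hexyl, or a group of another kind, such as an amine or a carboxylic acid, would fall on either core. Going by these compounds, it also remains open whether the step would keep its direction and size on a core other than these two.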